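Adding an ethoxycarbonyl group to compound 2

A few compounds are considered here, and "the series" means these few. Any claim that something is new, unique, unknown or untested is made for them only; others in the source may bear on it.

- Compound 1 `CCOC(=O)C#CC(O/C=C/C(=O)OC)C(C)C`: 960 nM
- Compound 2 `C#CCO/C=C/C(=O)OC`: > 100000 nM

In a functional assay on SW1573 cells (Homo sapiens) for antiproliferative activity, read by sulforhodamine B assay, with a stated time of 48 h (a lower number here means a stronger inhibitor of growth, a higher number a weaker inhibitor of growth), compound 2 stands at > 100000 nM, which is a limit of the assay and not a number.

Compound 3 `CCOC(=O)C#CCO/C=C/C(=O)OC` differs from compound 2 in one place, with ethoxycarbonyl in place of hydrogen on a triple-bonded carbon as the change. Compound 1 also carries this group and gives 960 nM in this assay, so much stronger growth inhibition is expected. The expected step of an at least 25-fold lower number from compound 2 to compound 3 (1.39 log units; beyond the scatter) is large and beyond the usual scatter. Compound 3 is estimated at 4000 nM, with an expected range from 1000 nM to 20000 nM.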

Compound 3, concentration for 50% growth inhibition: 1800 nM
Estimate against measurement, compound 3: 2.2-fold (0.35 log units) above; low and high end bracket the measured number.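

In this assay ethoxycarbonyl in place of hydrogen on a triple-bonded carbon is enough on its own to give a large step (an at least 55-fold lower number from compound 2 to compound 3 (1.74 log units; beyond the scatter)). Compound 2 stands at a limit of the assay and not a number: the limit of > 100000 nM in this assay, at which 1 of the 3 values shown sits. Isopropyl in place of hydrogen on the saturated chain carbon makes no difference that can be told apart (a 1.9-fold higher number from compound 1 to compound 3 (0.27 log units; within the scatter)).

From the compounds shown here alone, whether a carboxylic acid or an amide could replace the ethoxycarbonyl group on the triple-bonded carbon stays open. So does the effect of a longer chain on the saturated chain carbon.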